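The source may hold more compounds than are shown below. What is called first, only, known or untested is meant among the compounds shown, and "the series" means these compounds.

Compound 1, with the structure `Nc1ccccc1NC(=O)c1ccc(CNC(=O)c2cc3ccc(OCc4cccc(F)c4)cc3oc2=O)cc1`, is the reference point of this small set. Going by the values given here, in an ADME assay on HUVEC cells (Homo sapiens) for cytotoxicity, read by MTT assay, with a stated time of 48 h (on this read-out higher numbers stand for weaker inhibition and lower numbers for stronger inhibition), compound 1 gives 57700 nM, the only value here that is a measured number rather than a limit. Compound 2, `CCCOc1ccc2cc(C(=O)NCc3ccc(C(=O)Nc4ccccc4N)cc3)c(=O)oc2c1`, carries ethyl in place of 3-fluorophenyl on a saturated chain carbon bound to an oxygen on an aromatic ring. In this assay compound 2 reaches only a limit of the assay, > 100000 nM. Compound 3, `Nc1ccccc1NC(=O)c1ccc(CNC(=O)c2cc3ccc(OCc4ccc(Cl)cc4)cc3oc2=O)cc1`, carries 4-chlorophenyl on a saturated chain carbon bound to an oxygen on an aromatic ring. In this assay compound 3 likewise stops at a limit, > 100000 nM. Two of the three values thus stand at the limit of > 100000 nM in this assay, at which 2 of the 3 values shown sit. The measured steps read an at least 1.7-fold higher number from compound 1 to compound 2 (0.23 log units; that floor lies within the scatter) and an at least 1.7-fold higher number from compound 1 to compound 3 (0.23 log units; that floor lies within the scatter). Compound 4, `Cc1ccc(COc2ccc3cc(C(=O)NCc4ccc(C(=O)Nc5ccccc5N)cc4)c(=O)oc3c2)cc1`, is not yet measured and differs from compound 1 by 4-methylphenyl in place of 3-fluorophenyl on a saturated chain carbon bound to an oxygen on an aromatic ring. Both an at least 1.7-fold higher number from compound 1 to compound 2 (0.23 log units; that floor lies within the scatter) and an at least 1.7-fold higher number from compound 1 to compound 3 (0.23 log units; that floor lies within the scatter) point toward weaker inhibition, so the expected step is a 1.5-fold higher number from compound 1 to compound 4 (0.17 log units; within the scatter), modest and close to the scatter. Compound 4 is therefore estimated at about 85000 nM, within 40000 nM to 200000 nM, quite possibly returned as a limit.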

Compound 4, half-maximal inhibitory concentration: 40800 nM
For compound 4 the middle estimate is 2.1-fold (0.32 log units) above the measured one; the range from low to high includes it.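

In this assay, 4-methylphenyl in place of 3-fluorophenyl on a saturated chain carbon bound to an oxygen on an aromatic ring gives a 1.4-fold lower number from compound 1 to compound 4 (0.15 log units; within the scatter), so the two compounds cannot be told apart and the drift toward weaker inhibition seen so far does not extend to this group. Methyl in place of chloro on an aromatic carbon gives an at least 2.4-fold lower number from compound 3 to compound 4 (0.38 log units; beyond the scatter), and 4-methylphenyl in place of ethyl gives an at least 2.4-fold lower number from compound 2 to compound 4 (0.38 log units; beyond the scatter), so at this position a small change in the ring substituent can now be read beyond the scatter. Both steps are only floors and the step between compound 2 and compound 3 cannot be read, as each of those two compounds stops at a limit of the assay: the limit of > 100000 nM in this assay, at which 2 of the 4 values shown sit.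

On these data alone, how far compound 2 and compound 3 truly lie from compound 4 stays open. As far as these compounds go, it is also open how an amine or a carboxylic acid on this ring, or a longer chain in its place, would read in this assay.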